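Phenyl on the hydrazide nitrogen: compound 1 to compound 3

A few compounds are considered here, and "the series" means these few. Any claim that something is new, unique, unknown or untested is made for them only; others in the source may bear on it.

compound 1 `NNC(=O)c1c(N)sc2c1CCCCC2` — 51%
compound 2 `NNC(=O)c1c(N)sc2c1CCCCCC2` — 48%

For the measured compounds named here, in a functional assay on CHO cells for agonist activity at adenosine receptor A1 (Homo sapiens), read by ERK phosphorylation, tested at 10 uM (a higher number here means a stronger effect of the compound at the concentration tested, a lower number a weaker effect), compound 1 gives 51%, the higher of the two numbers measured so far. Compound 2 in this assay gives 48%, which lies within the scatter of compound 1, so no order between them is claimed. Compound 3 `Nc1sc2c(c1C(=O)NNc1ccccc1)CCCCC2` has not been measured; it differs from compound 1 by phenyl in place of hydrogen on an amine nitrogen. Going by the values given here, no step between measured compounds bears on this change, and none beyond the scatter is expected in this assay. Compound 3 is estimated at 46% (range 20% to 70%), an expected step of a number 5 percentage points lower from compound 1 to compound 3 (within the scatter).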

Compound 3, a percentage reported as activity, at one concentration (the size of the read-out at that concentration, not a potency): 42%
Beside the measured number, compound 3's estimate is 4 percentage points above it; measured number inside the range.
By their numbers in this assay, from the lowest: compounds 3, 2 and 1 (each within the scatter of the next).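

In this assay, amino to anilino gives a number 9 percentage points lower from compound 1 to compound 3 (within the scatter), so this amine nitrogen takes phenyl, with its six-membered aromatic ring, without a step beyond the scatter. The hydrogen at this place is therefore not shown to be required for the read-out at the concentration tested. No measurement at hand bears on why the read-out holds with this change.

Open, going by these compounds, is whether methyl, a benzyl group or a phenyl carrying a carboxylic acid or an amine on this nitrogen would also hold the read-out. Also open, on these data alone, is whether anilino behaves the same on the core of compound 2.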